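The source may report more compounds than this note shows. Statements on the series, on what has been measured and on what is new or still open speak of the compounds shown alone.

Compound 3 `CNCC(=O)N1N=C(c2cc3ccccc3oc2=O)CC1c1ccccc1` gives 12800 nM in a functional assay on MGC-803 cells (Homo sapiens) for cytotoxicity, read by MTT assay, with a stated time of 48 h (a higher number here means a weaker inhibitor, a lower number a stronger inhibitor), the second highest of the three numbers recorded. Compound 2 `CC(=O)Oc1ccccc1C1CC(C)=NN1C(=O)CN1CCCCC1` gives 4890 nM in this assay, a smaller number than that of compound 3 by a margin beyond the scatter. Compound 1 `CCC(=O)N1N=C(C)CC1c1cc(Br)cc(Br)c1O` gives 38600 nM in this assay, a larger number than that of compound 3, again beyond the scatter. Compound 4 `CC1CC(C)CN(CC(=O)N2N=C(c3cc4ccccc4oc3=O)CC2c2ccccc2)C1` has not yet been measured in this assay. It differs from compound 3 in one place: 3,5-dimethylpiperidin-1-yl in place of methylamino on a saturated chain carbon bound to a carbonyl carbon. Within the data shown here, no measured pair shows this change directly, so the expectation rests on the three values alone. A modest downward step is expected, a 2.0-fold lower number from compound 3 to compound 4 (0.29 log units; within the scatter). Compound 4 is estimated at 6500 nM, with a range from 2200 nM to 19000 nM.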

Compound 4, half-maximal inhibitory concentration: "not active" (no number reported)
No number was reported for compound 4; there is nothing to compare the estimate with.
By their numbers in this assay, from the lowest: compound 2; then compound 3; then compound 1.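

Among these compounds, compound 4 is reported as "not active" in this assay with no number, so no step from compound 3 can be read. Nothing shown accounts for this result. The compounds shown leave open how far methylamino and 3,5-dimethylpiperidin-1-yl differ in this assay.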